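Fluoro on the Benzyl Ring and Vero Cell Cytotoxicity

The source may hold more compounds than are shown below. What is called first, only, known or untested is meant among the compounds shown, and "the series" means these compounds.

Compound 2 `CC(=O)OC[C@H]1O[C@@H](CC(=O)/C=C2\C(=O)N(Cc3ccccc3)c3ccc(Cl)cc32)[C@H](OC(C)=O)[C@@H](OC(C)=O)[C@@H]1OC(C)=O` carries a benzyl group on the ring nitrogen of the shared core. In an ADME assay on Vero cells (Chlorocebus sabaeus) for cytotoxicity, read by resazurin assay, with a stated time of 72 h (on this read-out higher numbers stand for lower toxicity in this test and lower numbers for higher toxicity in this test), compound 2 gives 91200 nM. Compound 1 `CCCN1C(=O)/C(=C\C(=O)C[C@@H]2O[C@H](COC(C)=O)[C@@H](OC(C)=O)[C@H](OC(C)=O)[C@H]2OC(C)=O)c2cc(Cl)ccc21`, the ethyl analogue, gives 95600 nM in this assay, and the step of a 1.0-fold lower number from compound 1 to compound 2 (0.02 log units; within the scatter) shows that the two numbers lie within the scatter of each other, so neither compound can be called less or more toxic on this read-out.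

Compound 3 `CC(=O)OC[C@H]1O[C@@H](CC(=O)/C=C2\C(=O)N(Cc3ccc(F)cc3)c3ccc(Cl)cc32)[C@H](OC(C)=O)[C@@H](OC(C)=O)[C@@H]1OC(C)=O` differs from compound 2 by a single change: fluoro in place of hydrogen on an aromatic carbon. For the measured compounds named here, no measured pair shows this exact change, so the only guidance is the step from compound 1 to compound 2, where a larger swap of the whole group on the nitrogen left the number unchanged within the scatter. For compound 3 the step of a 1.0-fold lower number from compound 2 to compound 3 (0.01 log units; within the scatter) is therefore expected to stay within the scatter, in no particular direction. Compound 3 is estimated to give about 90000 nM in this assay, with a range from 45000 nM to 180000 nM.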

Compound 3, half-maximal cytotoxic concentration: 107000 nM
For compound 3 the middle estimate is 1.2-fold (0.08 log units) below the measured one; the range from low to high includes it.
By their numbers in this assay, from the lowest: compounds 2, 1 and 3 (each within the scatter of the next).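

For the compounds shown here, until now, the only comparison swapped the whole group on the ring nitrogen. Compound 3 tests a much smaller edit on the aromatic ring of that group, and in this assay fluoro on this carbon, para to a large group, gives a 1.2-fold higher number from compound 2 to compound 3 (0.07 log units; within the scatter), so benzyl and 4-fluorobenzyl cannot be told apart on this read-out. The wider comparison gives a 1.1-fold higher number from compound 1 to compound 3 (0.05 log units; within the scatter), which places all three groups on the nitrogen, ethyl-bearing, benzyl and 4-fluorobenzyl, within the ordinary noise of this test, and nothing available explains this result.

Fluoro is only one small substituent at one place, so these compounds leave open whether a larger or very different group, such as an amine or a carboxylic acid, on the same aromatic carbon would also leave the number within the scatter. They also leave open whether a longer chain on the ring nitrogen would do the same, and since no two of these three compounds can be separated here, nothing yet shows which changes to this part of the molecule would move the read-out at all.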